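Bicyclic amine in place of 4-isopropylpiperazin-1-yl: compound 4

The source may report more compounds than this note shows. Statements on the series, on what has been measured and on what is new or still open speak of the compounds shown alone.

Compound 3 `CC(C)N1CCN(c2cccc3c2C[C@H](CN(C)[C@H]2CCCc4cccnc42)NC3)CC1` gives 16.9 nM in a functional assay on CCRF-CEM cells for antagonist activity at C-X-C chemokine receptor type 4 (Homo sapiens), read by calcium flux, with stated times of 25 min and 90 s (on this read-out higher numbers stand for weaker inhibition and lower numbers for stronger inhibition), the lowest of the three numbers recorded so far. Compound 2 `CN(C[C@H]1Cc2c(cccc2N2CCN(C3CC3)CC2)CN1)[C@H]1CCCc2cccnc21` gives 23.5 nM in this assay, and the gap between the two is within the scatter. Compound 1 `C[C@@H]1CN(c2cccc3c2C[C@H](CN(C)[C@H]2CCCc4cccnc42)NC3)C[C@H](C)N1` gives 61 nM in this assay, the furthest from compound 3 and clearly separated from it.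

Compound 4 `CN(C[C@H]1Cc2c(cccc2N2CCN3CCC[C@H]3C2)CN1)[C@H]1CCCc2cccnc21` carries a group of 9 heavy atoms (7 carbon, 2 nitrogen; one five-membered non-aromatic ring with 1 hetero atom, one six-membered non-aromatic ring with 2 hetero atoms) in place of a group of 9 heavy atoms (7 carbon, 2 nitrogen; one six-membered non-aromatic ring with 2 hetero atoms), on an aromatic carbon. The entering group, like the one that leaves, has two nitrogen atoms and no hydrogen-bond donor.

Going by the values given here, three measured steps bear on this. From compound 1 to compound 3 a 3.6-fold lower number from compound 1 to compound 3 (0.56 log units; beyond the scatter) and from compound 1 to compound 2 a 2.6-fold lower number from compound 1 to compound 2 (0.41 log units; beyond the scatter) show that exchanging 3,5-dimethylpiperazin-1-yl for a piperazine bearing an alkyl on the ring nitrogen lowered the number modestly. The step from compound 2 to compound 3 a 1.4-fold lower number from compound 2 to compound 3 (0.14 log units; within the scatter) shows that isopropyl against cyclopropyl on that nitrogen stays within the scatter. The new group in compound 4 keeps both nitrogens fully substituted, as in compounds 2 and 3, so no step beyond the scatter is expected in this assay; the expected step from compound 3 to compound 4 is a 1.2-fold higher number from compound 3 to compound 4 (0.07 log units; within the scatter).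

Compound 4 is therefore estimated at 20 nM in this assay, within a range of 8 nM to 50 nM.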

Compound 4, half-maximal inhibitory concentration: 2.92 nM
Estimate against measurement, compound 4: 6.8-fold (0.84 log units) above, and the stated range ends above it.
By their numbers in this assay, from the lowest: compound 4; then compounds 3 and 2 (each within the scatter of the next); then compound 1.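

In this assay, the group with one five-membered and one six-membered non-aromatic ring gives a 5.8-fold lower number from compound 3 to compound 4 (0.76 log units; beyond the scatter) and an 8.0-fold lower number from compound 2 to compound 4 (0.91 log units; beyond the scatter), whereas exchanging cyclopropyl for isopropyl on the piperazine nitrogen gave only a 1.4-fold lower number from compound 2 to compound 3 (0.14 log units; within the scatter), a step within the scatter. Between compound 3 and compound 4 the counts of heavy atoms, carbons, nitrogens, hydrogen-bond donors and hydrogen-bond acceptors do not change, so at this aromatic carbon the number depends on more than those counts; what differs is the second ring and the defined stereocentre that come with the entering group. Against the 3,5-dimethylpiperazin-1-yl group the change gives a 21-fold lower number from compound 1 to compound 4 (1.32 log units; beyond the scatter) and is the only step in the series printed as large, leaving compound 4 with the lowest number of the four compounds.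

No evidence is at hand on what lies behind this step. Still open, from the compounds shown here alone, are how the opposite configuration at the defined stereocentre of compound 4 would read, and whether a 4-methylpiperazin-1-yl or a morpholin-4-yl group at this aromatic carbon would fall with compound 2 and compound 3 or nearer to compound 4.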